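Aromatase inhibition: phenyl for propyl on the triazole-bearing series

The compounds below may be only part of what the source reports. "The series", "measured", "known", "first", "only" and "open" are said of these compounds alone.

Measured so far:
compound 1 `COc1ccc(OCc2cn(C(c3ccc(C#N)cc3)c3ccc(C#N)cc3)nn2)cc1` — 12200 nM
compound 2 `CCCc1cn(C(c2ccccc2)c2ccccc2)nn1` — 11000 nM

Both measured compounds were tested in an assay on isolated protein for inhibition of Aromatase (Homo sapiens), read by fluorescence and colorimetric assay, with a stated time of 30 min; on this read-out higher numbers stand for weaker inhibition and lower numbers for stronger inhibition. Compound 1 gives 12200 nM and compound 2 gives 11000 nM; the two numbers lie within the scatter of each other, so neither can be set apart from the other on this read-out. Going by the values given here, no pair differing in one place has been measured, so the series offers no direct step to lean on.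

Compound 3 `c1ccc(-c2cn(C(c3ccccc3)c3ccccc3)nn2)cc1` is the next structure to be tested. Compared with compound 2 it carries phenyl in place of propyl on an aromatic carbon. Among the compounds with values here, with no comparable step on hand, the change is expected to stay near the scatter, leaning if anything toward stronger inhibition. The expected change is a 1.4-fold lower number from compound 2 to compound 3 (0.14 log units; within the scatter). In this assay compound 3 is estimated at 8000 nM, with a range from 3000 nM to 25000 nM.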

Compound 3, half-maximal inhibitory concentration: 12900 nM
Compound 3: the middle estimate sits 1.6-fold (0.21 log units) below what was measured; the measured number falls inside the stated range.
By their numbers in this assay, from the lowest: compounds 2, 1 and 3 (each within the scatter of the next).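

In this assay, going by these compounds alone, phenyl in place of propyl on the aromatic carbon gives a 1.2-fold higher number from compound 2 to compound 3 (0.07 log units; within the scatter), the first one-place step. This position therefore accepts a six-membered aromatic ring of carbon only in place of the open chain with no change beyond the scatter, and the two groups cannot be told apart on this read-out. No measured evidence on hand bears on this result.

As far as these compounds go, whether an amine, a carboxylic acid or a longer chain on this same aromatic carbon would move the number beyond the scatter remains open. Compound 1 differs from compound 2 and compound 3 in more than one place, so the contribution of its nitrile groups cannot be read from these compounds.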